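This account rests on a few compounds, and the source may have more. Where it says the series, first, only, none or still open, it means among the compounds named here.

Compound 1 `COc1ccc(Nc2ccc3c(C4CCN(C)CC4)c[nH]c3c2)cc1OC`: 200000 nM
Compound 2 `Fc1ccc(Nc2ccc3c(C4CCNCC4)c[nH]c3c2)cc1F`: 178000 nM
Compound 3 `Cn1cc(C2CCNCC2)c2ccc(Nc3ccc(F)c(F)c3)cc21`: 169000 nM

These values come from a physicochemical assay for solubility, in phosphate buffer, at pH 7.4 (a lower number here means a less soluble compound, a higher number a more soluble compound), and compound 2 lies within the scatter of both other compounds. Compound 4 `CN1CCC(c2c[nH]c3cc(Nc4ccc(F)c(F)c4)ccc23)CC1` is compound 2 with methyl in place of hydrogen on an amine nitrogen in a ring. Going by the values given here, the one measured methyl step, a 1.1-fold lower number from compound 2 to compound 3 (0.02 log units; within the scatter), places methyl on an aromatic nitrogen instead, so it bears on this change only indirectly. Compound 1 also carries 1-methylpiperidin-4-yl, differs elsewhere, and gives 200000 nM. No change beyond the scatter is therefore expected in this assay. The estimated step is a 1.0-fold lower number from compound 2 to compound 4 (0.02 log units; within the scatter). For compound 4 the expected value is 170000 nM, with an estimated range of 100000 nM to 215000 nM.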

Compound 4, solubility: 200000 nM
Beside the measured number, compound 4's estimate is 1.2-fold (0.07 log units) below it, and the stated range covers the measured number.
By their numbers in this assay, from the lowest: compounds 3, 2, 1 and 4 (each within the scatter of the next).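

In this assay methyl in place of hydrogen on the amine nitrogen in the ring gives a 1.1-fold higher number from compound 2 to compound 4 (0.05 log units; within the scatter) and so does not separate piperidin-4-yl from 1-methylpiperidin-4-yl at this position. The earlier measured methyl step lay on an aromatic nitrogen, whereas this one reads the change directly on the amine nitrogen. No measurement shown accounts for this result.
Still open, on these data alone, is whether a longer chain or an acetyl group on this amine nitrogen would also stay within the scatter.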